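The compounds below may be only part of what the source reports. "The series", "measured", "known", "first", "only" and "open" are said of these compounds alone.

Measured compounds:
- compound 1, `CC1CCN(C[C@H](O)[C@]23CC[C@H](CC2=O)C3(C)C)CC1`, in an ADME assay on HEK-293T cells (Homo sapiens) for cytotoxicity, read by MTT assay, with a stated time of 72 h (a higher number here means a weaker inhibitor, a lower number a stronger inhibitor), gives 158000 nM
- compound 2, `CC1(C)[C@@H]2CC[C@@]1([C@@H](O)CN1CCN(c3ccc(Cl)cc3)CC1)C(=O)C2`, in this assay gives 8600 nM

Of these two numbers, compound 1 has the higher one, which in this assay means the weaker effect on cell growth; compound 2 sits well below it, and that gap lies beyond the usual scatter of repeated measurements. For the measured compounds named here, no step between two measured compounds that differ in only one place has been recorded, so there is no direct precedent for small edits to the amine ring.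

Compound 3, `CC1(C)[C@@H]2CC[C@@]1([C@@H](O)CN1CCCCC1)C(=O)C2`, is the next compound. It differs from compound 1 in one place: hydrogen in place of methyl on a saturated ring carbon. The shared core and the alcohol are untouched; only a single carbon is removed from the saturated ring.

Since this is such a small change, the expected step of a 1.1-fold lower number from compound 1 to compound 3 (0.02 log units; within the scatter) is small, most likely no difference beyond the scatter, with no clear direction. For compound 3 the expected value in this assay is therefore 150000 nM, with a plausible range from 60000 nM to 400000 nM.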

Compound 3, half-maximal inhibitory concentration: 143000 nM
Compound 3: the middle estimate sits 1.0-fold (0.02 log units) above what was measured, and the stated range covers the measured number.
By their numbers in this assay, from the lowest: compound 2; then compounds 3 and 1 (each within the scatter of the next).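

Swapping methyl for hydrogen on the saturated ring carbon, three ring bonds from the ring nitrogen, gives in this assay a 1.1-fold lower number from compound 1 to compound 3 (0.04 log units; within the scatter), and this is the first direct reading of a single edit to the amine ring. The step lies within the usual scatter of repeated measurements, so the two numbers cannot be told apart, and for this pair the methyl has no readable effect on the result. Nothing at hand gives a reason for this outcome.

The compounds shown cover only hydrogen and methyl at this carbon, so it remains open whether a longer chain such as ethyl, a phenyl ring or a carboxylic acid in the same place would also leave the number within the scatter. On these data alone, it is equally open whether methyl and hydrogen would stay indistinguishable on a different amine ring, or whether this result holds only for the pair of compounds at hand.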